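Aryl replacement on the shared core: compound 3 to compound 4

This account rests on a few compounds, and the source may have more. Where it says the series, first, only, none or still open, it means among the compounds named here.

Among the compounds with values here, compound 3 `COc1ccc(-c2cc(N3CCC(CCNS(N)(=O)=O)CC3)ncn2)cc1` gives 56600 nM in a functional assay on MCF7 cells (Homo sapiens) for antiproliferative activity, read by sulforhodamine B assay, with a stated time of 48 h (on this read-out higher numbers stand for weaker inhibition of growth and lower numbers for stronger inhibition of growth), the highest of the three numbers so far. Compound 1 `COc1ccc(-c2cc(N3CCC(CNS(N)(=O)=O)CC3)ncn2)cc1` gives 35300 nM, and the step of a 1.6-fold higher number from compound 1 to compound 3 (0.21 log units; within the scatter) is within the scatter, so the two cannot be ordered. Compound 2 `CCCCc1ccc(-c2cc(N3CCC(CCNS(N)(=O)=O)CC3)ncn2)cc1` gives 11300 nM; the step of a 5.0-fold higher number from compound 2 to compound 3 (0.70 log units; beyond the scatter) shows that the group on the aryl ring moves the number by a modest amount.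

Compound 4 `NS(=O)(=O)NCCC1CCN(c2cc(-c3ccccc3F)ncn2)CC1` differs from compound 3 by 2-fluorophenyl in place of 4-methoxyphenyl on an aromatic carbon. Within the data shown here, only the step from compound 2 to compound 3 bears on this change, and it concerns a different pair of groups on the same ring, so it sets the scale of what an aryl change can do rather than its direction. The expectation for compound 4 is therefore a step of a 1.9-fold lower number from compound 3 to compound 4 (0.28 log units; within the scatter) in this assay, with a lower number somewhat more likely than a higher one because the methoxy analogue compound 3 gives 56600 nM, the highest number seen. Compound 4 is estimated at 30000 nM, within 9000 nM to 90000 nM.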

Compound 4, concentration for 50% growth inhibition: > 100000 nM
Compound 4: only a limit was reported (the forecaster's own chance of this, stated with the estimate: 10%); middle value at least 3.3-fold (0.52 log units) away from the limit.
By their numbers in this assay, from the lowest: compound 2; then compounds 1 and 3 (each within the scatter of the next). At a limit, above all of these: compound 4.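

In this assay compound 4 sits at a limit of the assay and not at a number: the limit of > 100000 nM in this assay, at which 1 of the 4 values shown sits.

With 2-fluorophenyl in place of 4-methoxyphenyl the reading is an at least 1.7-fold higher number from compound 3 to compound 4 (0.24 log units; that floor lies within the scatter), so this change gives no measurable gain at this aromatic carbon, but the floor alone does not order the two compounds. Beside a 5.0-fold higher number from compound 2 to compound 3 (0.70 log units; beyond the scatter), this position now carries a second kind of aryl change, and within these steps only the butyl group of compound 2 separates from the methoxy group of compound 3 beyond the scatter.

On these data alone, how far compound 4 lies past its limit stays open, and with it the true size of the step. Also open, as far as these compounds go, is whether an amine, a carboxylic acid or an alkyl chain longer than butyl on this aryl ring would shift the number in either direction.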